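This account rests on a few compounds, and the source may have more. Where it says the series, first, only, none or still open, it means among the compounds named here.

Three compounds share one core and differ only in the ring attached to the carbonyl. In an assay on C3H 10T1/2 cells for inhibition of Sonic hedgehog protein (Mus musculus), read by a luciferase reporter (on this read-out higher numbers stand for weaker inhibition and lower numbers for stronger inhibition), compound 1 `Cc1ccc(C(=O)Nc2ccc(Cl)c(-c3ccccn3)c2)c(C)n1` gives 130 nM. Compound 2 `O=C(Nc1ccc(Cl)c(-c2ccccn2)c1)c1ccccc1` gives 800 nM in this assay, the highest of the three numbers, and compound 3 `O=C(Nc1ccc(Cl)c(-c2ccccn2)c1)c1ccccc1Cl` gives 110 nM. Within the data shown here, two measured steps touch this ring: a 6.2-fold higher number from compound 1 to compound 2 (0.79 log units; beyond the scatter), and a 7.3-fold lower number from compound 2 to compound 3 (0.86 log units; beyond the scatter). Compound 4 `CS(=O)(=O)c1ccc(C(=O)Nc2ccc(Cl)c(-c3ccccn3)c2)cc1` differs from compound 2 by methylsulfonyl in place of hydrogen on an aromatic carbon. Both steps show that the bare phenyl of compound 2 gives the highest number and that a group on this ring lowers it, though neither involves a methylsulfonyl group, so the size is uncertain. A somewhat lower number is therefore expected, a 1.6-fold lower number from compound 2 to compound 4 (0.20 log units; within the scatter). Compound 4 is estimated at 500 nM, between 120 nM and 2000 nM.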

Compound 4, half-maximal inhibitory concentration: 40 nM
Beside the measured number, compound 4's estimate is 13-fold (1.10 log units) above it, outside the stated range (below it).
By their numbers in this assay, from the lowest: compound 4; then compounds 3 and 1 (each within the scatter of the next); then compound 2.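

Methylsulfonyl on the aromatic carbon para to a large group gives a 20-fold lower number from compound 2 to compound 4 (1.30 log units; beyond the scatter), a large step. This shows that the ring of compound 2 accepts a group at this position, one with no ring and two double bonds outside aromatic rings, and that the number then falls rather than rises. Nothing measured here explains the size of this drop.

Methylsulfonyl is the only group shown at this position, so it remains open whether the drop is specific to it. A nitrile, an amine or a carboxylic acid at the same carbon could give a similar or a very different number.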